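The source may report more compounds than this note shows. Statements on the series, on what has been measured and on what is new or still open speak of the compounds shown alone.

In a functional assay on G-361 cells (Homo sapiens) for cytotoxicity, read by MTT assay, with a stated time of 3 days; a higher number here means a weaker inhibitor, a lower number a stronger inhibitor:

- Compound 1 `CCNc1nc(SCc2nc3ccccc3[nH]2)nc(-c2ccccc2)c1C#N`: 4.38 nM
- Compound 2 `N#Cc1c(NC(N)=S)nc(SCc2nc3ccccc3[nH]2)nc1-c1ccccc1`: 5.81 nM

Compound 2 stands within the usual scatter of compound 1, so these two numbers cannot be told apart. Compound 3 `N#Cc1c(NC(N)=O)nc(SCc2nc3ccccc3[nH]2)nc1-c1ccccc1` differs from compound 2 at one place: a group of 3 heavy atoms (1 carbon, 1 nitrogen, 1 oxygen; no ring) in place of a group of 3 heavy atoms (1 carbon, 1 nitrogen, 1 sulfur; no ring), on a nitrogen on an aromatic ring. The enering group is a carbamoyl, on a nitrogen on an aromatic ring. Going by the values given here, only one measured step bears on this, a 1.3-fold higher number from compound 1 to compound 2 (0.12 log units; within the scatter), which also changed a group at that place and stayed within the scatter. Among the compounds with values here, no measured pair shows this exact exchange, so the guide is thin, and no step beyond the scatter is expected in this assay. The estimated step is small, a 1.0-fold higher number from compound 2 to compound 3 (0.01 log units; within the scatter). For compound 3 the expected value is 6 nM, with an estimated range of 2.5 nM to 15 nM.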

Compound 3, half-maximal inhibitory concentration: 2.55 nM
The estimate for compound 3 lay 2.4-fold (0.37 log units) above the measured number; the measured number falls inside the stated range.
By their numbers in this assay, from the lowest: compounds 3, 1 and 2 (each within the scatter of the next, the first and the last beyond it).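

In this assay, going by these compounds alone, exchanging the sulfur of the group on the aromatic-ring nitrogen for oxygen, which gives the carbamoyl, brings the first step at this place that lies beyond the scatter, with a 2.3-fold lower number from compound 2 to compound 3 (0.36 log units; beyond the scatter) in the number. Carbamoyl in place of ethyl, by contrast, gives a 1.7-fold lower number from compound 1 to compound 3 (0.23 log units; within the scatter) and so cannot be told apart from no change. No measurement here explains why the oxygen and sulfur groups differ.

As far as these compounds go, what a longer chain such as propyl, or an acetyl group, would do on this nitrogen remains open.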